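Replacing a Urea Aryl Group with a Fused Bicyclic Ketone

The source may hold more compounds than are shown below. What is called first, only, known or untested is meant among the compounds shown, and "the series" means these compounds.

Measured so far:
- compound 1 `COc1cc(Nc2ncnc3c(NC(=O)Nc4cc(Cl)c(Cl)cc4Cl)cccc23)cc(OC)c1`: 4890 nM
- compound 2 `COc1cc(Nc2ncnc3c(NC(=O)Nc4ccc5c(c4)OCCO5)cccc23)cc(OC)c1`: 2750 nM
- compound 3 `CCOC(=O)c1ccc(NC(=O)Nc2cccc3c(Nc4cc(OC)cc(OC)c4)ncnc23)cc1`: 317 nM

The three compounds share a core and differ only in the group attached to the urea nitrogen. In a functional assay on RT-112 cells (Homo sapiens) for antiproliferative activity, read by MTT assay, with a stated time of 72 h (a higher number here means a weaker inhibitor of growth, a lower number a stronger inhibitor of growth), compound 1 gives the highest of the three numbers. Its nearest neighbour is compound 2, with a 1.8-fold lower number from compound 1 to compound 2 (0.25 log units; within the scatter). The step to compound 3 is a 15-fold lower number from compound 1 to compound 3 (1.19 log units; beyond the scatter), and from compound 2 to compound 3 there is an 8.7-fold lower number from compound 2 to compound 3 (0.94 log units; beyond the scatter).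

Compound 4 `COc1cc(Nc2ncnc3c(NC(=O)c4cc(=O)c5ccccc5o4)cccc23)cc(OC)c1` has not yet been measured. It differs from compound 1 in this way: a group of 11 heavy atoms (9 carbon, 2 oxygen; one six-membered aromatic ring of carbon only, one six-membered aromatic ring with 1 hetero atom) in place of a group of 10 heavy atoms (6 carbon, 1 nitrogen, 3 chlorine; one six-membered aromatic ring of carbon only), on a carbonyl carbon. This is not the same kind of change as in the measured steps: in those, a new group was put on the amide-type nitrogen, whereas here the nitrogen itself leaves together with the ring it carried, and the new group sits directly on the carbonyl carbon. Going by the values given here, no measured pair therefore bears on it directly. What the data do show is that leaving the trichlorophenyl group has so far never raised the number, and in compound 3 lowered it a great deal. A modest lowering is expected, a 2.4-fold lower number from compound 1 to compound 4 (0.39 log units; beyond the scatter), with wide uncertainty. For compound 4 the estimate in this assay is 2000 nM, expected to fall between 400 nM and 10000 nM.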

Compound 4, concentration for 50% growth inhibition: > 20000 nM
Compound 4: only a limit was reported; the forecaster's own chance of this, stated with the estimate: 5%; middle value at least 10-fold (1.00 log units) from the limit.
By their numbers in this assay, from the lowest: compound 3; then compounds 2 and 1 (each within the scatter of the next). At a limit, above all of these: compound 4.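

In this assay, compound 4 has no exact number, only a limit: the limit of > 20000 nM in this assay, at which 1 of the 4 values shown sits. Against every earlier compound the change goes the wrong way, with an at least 4.0-fold higher number from compound 1 to compound 4 (0.61 log units; beyond the scatter), an at least 7.2-fold higher number from compound 2 to compound 4 (0.86 log units; beyond the scatter) and an at least 63-fold higher number from compound 3 to compound 4 (1.79 log units; beyond the scatter). The earlier compounds shown here showed only what happens when one group on the amide-type nitrogen is exchanged for another, whereas this result shows that the position tolerates a much more drastic change poorly: when that nitrogen leaves with its ring and the new group sits directly on the carbonyl carbon, growth inhibition falls off even relative to compound 1, which had the highest number of the first three.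

Two things changed together in compound 4, the loss of the nitrogen and the arrival of a new ring system, so the compounds shown cannot say which of them matters. A plain phenyl group set directly on the carbonyl carbon, or the new ring system of compound 4 carried on an amide-type nitrogen, would separate the two.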